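Swapping the Hydroxyphenyl Ring on Compound 1

This account rests on a few compounds, and the source may have more. Where it says the series, first, only, none or still open, it means among the compounds named here.

Compound 1 `Cc1c(C(=O)N/N=C\c2ccc(O)cc2)oc2cccc(O)c12` is one of three compounds tested in a functional assay on PC-3 cells (Homo sapiens) for inhibition; on this read-out lower numbers stand for stronger inhibition and higher numbers for weaker inhibition; compound 1 gives 21700 nM, the second highest of the three numbers. Compound 2 `Cc1c(C(=O)N/N=C\c2ccccc2)oc2cccc(O)c12` gives 29200 nM, and the step of a 1.3-fold higher number from compound 1 to compound 2 (0.13 log units; within the scatter) stays within the scatter. Compound 3 `Cc1c(C(=O)N/N=C\c2c(O)cccc2F)oc2cccc(O)c12` gives 8050 nM, reached through a 2.7-fold lower number from compound 1 to compound 3 (0.43 log units; beyond the scatter) and through a 3.6-fold lower number from compound 2 to compound 3 (0.56 log units; beyond the scatter). Compound 4 `Cc1c(C(=O)N/N=C\c2cc(Cl)ccc2O)oc2cccc(O)c12` is not yet measured and differs from compound 1 in one place: 5-chloro-2-hydroxyphenyl in place of 4-hydroxyphenyl on a carbon with a double bond to nitrogen. The step that bears on this change is a 2.7-fold lower number from compound 1 to compound 3 (0.43 log units; beyond the scatter), which likewise brought in a ring carrying both a hydroxy and a halogen, so a modest lowering of the number is expected. Compound 4 is therefore estimated at 10000 nM, within a range from 4500 nM to 24000 nM, which means an expected step of a 2.2-fold lower number from compound 1 to compound 4 (0.34 log units; beyond the scatter).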

Compound 4, half-maximal inhibitory concentration: 3120 nM
Compound 4: the middle estimate sits 3.2-fold (0.51 log units) above what was measured; measured number outside the range, below it.
By their numbers in this assay, from the lowest: compound 4; then compound 3; then compounds 1 and 2 (each within the scatter of the next).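

The 5-chloro-2-hydroxyphenyl ring takes this position further than any earlier change did, with the biggest drops so far in this assay (a 7.0-fold lower number from compound 1 to compound 4 (0.84 log units; beyond the scatter); a 9.4-fold lower number from compound 2 to compound 4 (0.97 log units; beyond the scatter)). Among rings carrying both a hydroxy and a halogen, the choice of ring also matters, as 2-fluoro-6-hydroxyphenyl is not the best of the two (a 2.6-fold lower number from compound 3 to compound 4 (0.41 log units; beyond the scatter)). Nothing available explains these steps.

The compounds shown do not separate what the chlorine and the hydroxy each contribute. From the compounds shown here alone, whether bromine or a methoxy group would serve in place of the chlorine also remains open.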